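This account rests on a few compounds, and the source may have more. Where it says the series, first, only, none or still open, it means among the compounds named here.

Of the compounds shown here, two of a shared core have been tested in a functional assay on HCT-116 cells (Homo sapiens) for antiproliferative activity, read by MTT assay, with a stated time of 48 h (on this read-out higher numbers stand for weaker inhibition and lower numbers for stronger inhibition), so far. Compound 1 `CCOc1ccc(-n2nncc2CN2C(=O)C3(C(C#N)=C(N)Oc4c3c3nc5ccccc5nc3c3ccccc43)c3ccccc32)cc1` reaches only a limit, recorded as > 50000 nM rather than a number. Compound 2 `Cc1cccc(-n2nncc2CN2C(=O)C3(C(C#N)=C(N)Oc4c(N)cc5nc6ccccc6nc5c43)c3ccccc32)c1` likewise stops at a limit, recorded as > 50000 nM. Both values thus sit together at the edge of what can be reported, as the limit of > 50000 nM in this assay, at which 2 of the 2 values shown sit, shows, and neither compound can be placed above or below the other. Compound 3 `N#CC1=C(N)Oc2c(N)cc3nc4ccccc4nc3c2C12C(=O)N(Cc1cnnn1-c1ccccc1Br)c1ccccc12` has not yet been measured; it differs from compound 2 in one place: 2-bromophenyl in place of 3-methylphenyl on an aromatic nitrogen. Going by the values given here, no measured pair shows a change of this kind, so no direction can be drawn from the numbers at hand. The step that the limit leaves unreadable from compound 2 to compound 3 is therefore expected to stay within the usual scatter, with compound 3 most likely reported again as a limit. Compound 3 is expected to give about 60000 nM in this assay, within a range from 20000 nM to 200000 nM.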

Compound 3, half-maximal inhibitory concentration: 12400 nM
For compound 3 the middle estimate is 4.8-fold (0.68 log units) above the measured one, outside the stated range (below it).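

Swapping 3-methylphenyl for 2-bromophenyl on the aromatic nitrogen of the triazole gives the first readable change at this position in this assay: an at least 4.0-fold lower number from compound 2 to compound 3 (0.60 log units; beyond the scatter), and a lower number here means stronger inhibition. Compound 2 is recorded only as a limit, > 50000 nM. The step therefore has a known minimum but no known full size, and compound 3 is the only compound here with an actual number: the limit of > 50000 nM in this assay, at which 2 of the 3 values shown sit.

The two groups differ both in the substituent and in where it sits on the phenyl ring, so the compounds shown cannot separate the effect of the bromine from that of its place. Also open, as far as these compounds go, is how a plain phenyl group, or a phenyl carrying a chlorine or an amine, would compare at this position.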